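The compounds below may be only part of what the source reports. "The series", "measured", "known", "first", "only" and "open" are said of these compounds alone.

Compound 1 `Cc1cn2cc(-c3cc4ccc(N5CCNCC5)cc4c(=O)o3)nc2c(C)n1` is the lower of the two measured compounds in an ADME assay on Caco-2 cells (Homo sapiens) for permeability; a lower number here means that the compound crosses the layer more slowly, a higher number that the compound crosses the layer faster: compound 1 gives 4.4 10^-6 cm/s, whereas compound 2 `Cc1cn2nc(-c3cc(=O)n4cc(N5CCNCC5)ccc4n3)cc2c(C)n1` gives 14 10^-6 cm/s, a gap beyond the scatter. Compound 3 `Cc1cn2cc(-c3cc4ccc(N5CCN(C)CC5)cc4c(=O)o3)nc2c(C)n1` differs from compound 1 by methyl in place of hydrogen on an amine nitrogen in a ring. For the measured compounds named here, no measured pair differs in only one place, so no comparable step is known. For compound 3 the change is expected to raise the number, with an estimated step of a 1.8-fold higher number from compound 1 to compound 3 (0.26 log units; within the scatter) from compound 1. Compound 3 is therefore expected to give about 8 10^-6 cm/s, within a range from 4 10^-6 cm/s to 16 10^-6 cm/s.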

Compound 3, apparent permeability: 1.2 10^-6 cm/s
Estimate against measurement, compound 3: 6.7-fold (0.82 log units) above; the measured number lies below the stated range.
By their numbers in this assay, from the lowest: compound 3; then compound 1; then compound 2.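

Going from piperazin-1-yl to 4-methylpiperazin-1-yl gives a 3.7-fold lower number from compound 1 to compound 3 (0.56 log units; beyond the scatter) in this assay and is the first single-place comparison in this series. It shows that the amine nitrogen in this ring is a position where one added methyl moves the number down, by a step beyond the scatter. Nothing among the data gives a reason for this drop.

On these data alone, whether the same step holds on the core of compound 2 remains open. So does how a larger group on this nitrogen, such as ethyl or acetyl, would read.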